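This account rests on a few compounds, and the source may have more. Where it says the series, first, only, none or still open, it means among the compounds named here.

Measured compounds:
compound 1, `C[Se]/C(=N\C(=O)c1ccco1)NC(=O)c1ccco1`: 5940 nM
compound 2, `O=C(/N=C(/NC(=O)c1ccco1)[Se]Cc1ccccc1)c1ccco1`: 8800 nM
compound 3, `O=C(/N=C(/NC(=O)c1csc([N+](=O)[O-])c1)[Se]Cc1ccccc1)c1csc([N+](=O)[O-])c1`: 24400 nM

All three numbers come from an ADME assay on MCF-10A cells (Homo sapiens) for cytotoxicity, read by MTT assay, with a stated time of 72 h; on this read-out higher numbers stand for weaker inhibition of growth and lower numbers for stronger inhibition of growth. Compound 1 and compound 2 share one core; compound 3 is built on another, and the difference between the two cores is not broken down here. Compound 3 gives the highest number of the three; its gap to compound 2 is beyond the scatter, and its gap to compound 1 is wider still. Within the shared core of compound 1 and compound 2, the change is hydrogen in place of phenyl on a saturated chain carbon bound to a selenium atom, and the step read in this assay is a 1.5-fold lower number from compound 2 to compound 1 (0.17 log units; within the scatter).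

Compound 4, `C[Se]/C(=N\C(=O)c1csc([N+](=O)[O-])c1)NC(=O)c1csc([N+](=O)[O-])c1`, has not yet been measured. It stands to compound 3 exactly as compound 1 stands to compound 2: the change is hydrogen in place of phenyl on a saturated chain carbon bound to a selenium atom, the same change at the same place. Among the measured compounds shown here, the single measured instance of this change is the only thing to rest on. The expected step in this assay is a 1.4-fold lower number from compound 3 to compound 4 (0.13 log units; within the scatter), taken from a 1.5-fold lower number from compound 2 to compound 1 (0.17 log units; within the scatter), so no more than a small lowering is estimated. Compound 4 is expected at about 18000 nM, with a likely range from 8000 nM to 40000 nM.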

Compound 4, concentration for 50% growth inhibition: 1950 nM
Estimate against measurement, compound 4: 9.2-fold (0.97 log units) above, and the stated range ends above it.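

In this assay, hydrogen in place of phenyl on a saturated chain carbon bound to a selenium atom gives a 13-fold lower number from compound 3 to compound 4 (1.10 log units; beyond the scatter). The size of this step therefore does not carry over from one core to the other, and the two measured instances differ: the same change on two cores in this assay, a 1.5-fold lower number (0.17 log units; within the scatter) from compound 2 to compound 1 and a 13-fold lower number (1.10 log units; beyond the scatter) from compound 3 to compound 4, 8.4-fold (0.93 log units) apart, beyond the scatter of two such steps. Among the compounds shown here, with only two pairs, this shows that the step depends on the core, but not which feature of the core sets its size, and no rule for further cores follows.

The compounds shown carry only methyl and benzyl on the selenium atom, so it remains open how a longer chain such as butyl, or a chain ending in an amine or a carboxylic acid, would read on either core. On these data alone, it also remains open whether benzyl to methyl would give a step like that on the core of compound 1 or like that on the core of compound 3 on a third core.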